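Methyl on the ring nitrogen of compound 1

The compounds below may be only part of what the source reports. "The series", "measured", "known", "first", "only" and "open" are said of these compounds alone.

Compound 1 `CC1(c2ccc(-c3ccc4ccccc4c3)[nH]c2=O)OC(=O)NC1=O`: 20 nM
Compound 2 `O=C1NC(=O)C(c2ccc(-c3ccc4ccccc4c3)[nH]c2=O)(C2CCCCC2)O1`: 7.94 nM
Compound 3 `O=C1NC(=O)C(c2ccc(-c3ccc4ccccc4c3)[nH]c2=O)(C2CCOCC2)O1`: 200 nM

All three compounds were tested in a functional assay on CHO cells for antagonist activity at prostaglandin E2 receptor EP3 subtype (Homo sapiens), read by FLIPR, with a stated time of 1 h; on this read-out higher numbers stand for weaker inhibition and lower numbers for stronger inhibition. Compound 1 stands second highest of the three numbers: nearest to it is compound 2, with a 2.5-fold lower number from compound 1 to compound 2 (0.40 log units; beyond the scatter), and furthest is compound 3, with a 10-fold higher number from compound 1 to compound 3 (1.00 log units; beyond the scatter). Between the two neighbours lies a 25-fold higher number from compound 2 to compound 3 (1.40 log units; beyond the scatter). Each of these measured steps swaps the group on a saturated ring carbon; none of them touches the ring nitrogen.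

Compound 4 `CN1C(=O)OC(C)(c2ccc(-c3ccc4ccccc4c3)[nH]c2=O)C1=O` differs from compound 1 by methyl in place of hydrogen on an amide-type nitrogen in a ring. Within the data shown here, no measured step bears on this kind of change, so the expectation rests on no comparable pair and is correspondingly uncertain; the spread across compounds 1 to 3 shows only how much a single change of one group can move the number here. The expected step is a 4.0-fold higher number from compound 1 to compound 4 (0.60 log units; beyond the scatter), a modest move toward weaker inhibition, with wide uncertainty. The estimated value for compound 4 is 80 nM, with a range from 15 nM to 500 nM.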

Compound 4, inhibition constant: 501 nM
Compound 4: middle estimate off by 6.3-fold (0.80 log units), on the low side; the measured number lies above the stated range.
By their numbers in this assay, from the lowest: compound 2; then compound 1; then compound 3; then compound 4.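

Placing a methyl on the amide-type nitrogen in the ring gives, in this assay, a 25-fold higher number from compound 1 to compound 4 (1.40 log units; beyond the scatter) as its result. Among these compounds, this one added carbon therefore moves the number as far as the largest step among the earlier compounds, a 25-fold higher number from compound 2 to compound 3 (1.40 log units; beyond the scatter) on swapping cyclohexyl for oxan-4-yl, so the nitrogen matters in this small set as much as the saturated ring carbon does. Nothing measured here gives a reason for the size of this step.

A single pair cannot separate the loss of the amide hydrogen from the gain of the methyl, and an ethyl or a longer chain on this nitrogen remains an open case. As far as these compounds go, whether the same methyl would have a similar effect alongside the cyclohexyl of compound 2 also stays open.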